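The compounds below may be only part of what the source reports. "The series", "measured", "known", "first", "only" and "open" are said of these compounds alone.

Compound 1 `CC1=C(C(=O)Nc2ccc(Cl)c(Cl)c2)C(c2cccc(O)c2)NC(=S)N1` is the stronger of the two measured compounds here. In a functional assay on HOP-92 cells (Homo sapiens) for cytotoxicity, read by sulforhodamine B assay, with a stated time of 48 h (on this read-out higher numbers stand for weaker inhibition of growth and lower numbers for stronger inhibition of growth), compound 1 gives 13500 nM, the lowest of the two numbers. Within the data shown here, compound 2 `CC1=C(C(=O)Nc2ccc(Cl)c(Cl)c2)C(c2cccc(Cl)c2)NC(=O)N1` differs from it in more than one place, so no single step is drawn between them; in this assay compound 2 gives 45700 nM, a number beyond the scatter above that of compound 1. The unmeasured compound 3 `CC1=C(C(=O)Nc2ccc(Cl)c(Cl)c2)C(c2cccc(Oc3ccccc3)c2)NC(=S)N1` arises from compound 1 by one change: phenyl in place of hydrogen on an oxygen on an aromatic ring, which, cut one bond further out, reads hydroxy to phenoxy. Among the measured compounds shown here, no measured pair shows the effect of this change, so the expectation rests on compound 1 alone. The step from compound 1 to compound 3 in this assay is expected to be small, perhaps a slightly lower number or none beyond the scatter, a 1.4-fold lower number from compound 1 to compound 3 (0.13 log units; within the scatter). For compound 3 in this assay the estimate is 10000 nM, with a range from 3000 nM to 40000 nM.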

Compound 3, concentration for 50% growth inhibition: 13200 nM
Estimate against measurement, compound 3: 1.3-fold (0.12 log units) below, and the stated range covers the measured number.
By their numbers in this assay, from the lowest: compounds 3 and 1 (each within the scatter of the next); then compound 2.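

Phenyl in place of hydrogen on an oxygen on an aromatic ring, which reads hydroxy to phenoxy, gives a 1.0-fold lower number from compound 1 to compound 3 (0.01 log units; within the scatter) in this assay. This position therefore accepts six more heavy atoms, as one six-membered aromatic ring of carbon only, and the loss of the hydrogen on that oxygen without a shift beyond the scatter, which compound 1 and compound 2 could not show because they differ in more than one place. Nothing available explains why the number holds level.

The compounds shown leave open whether methoxy or benzyloxy on that ring, or an amine in place of the oxygen, would also hold the number. They also leave open what a carboxylic acid or a chlorine on the new phenyl ring would do.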